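Aryl substituent swaps in a small growth-inhibition series

The compounds below may be only part of what the source reports. "The series", "measured", "known", "first", "only" and "open" are said of these compounds alone.

Compound 1 `CC1=CC[C@H](C(C)(C)NC(=S)N/N=C/c2ccccc2Cl)CC1` and compound 2 `CC1=CC[C@H](C(C)(C)NC(=S)N/N=C/c2cccc(Cl)c2)CC1` share one core and differ as 3-chlorophenyl in place of 2-chlorophenyl on a carbon with a double bond to nitrogen. In a functional assay on OVCAR-3 cells (Homo sapiens) for inhibition, read by sulforhodamine B assay, with a stated time of 48 h (on this read-out lower numbers stand for stronger inhibition of growth and higher numbers for weaker inhibition of growth), compound 1 gives 15100 nM, and compound 2 gives 13600 nM; the step is a 1.1-fold lower number from compound 1 to compound 2 (0.05 log units; within the scatter). Compound 3 `CC1=CC[C@H](C(C)(C)NC(=S)N/N=C/c2ccccc2[N+](=O)[O-])CC1` carries the change nitro in place of chloro on an aromatic carbon relative to compound 1 and in this assay compound 3 gives 8500 nM, a step of a 1.8-fold lower number from compound 1 to compound 3 (0.25 log units; within the scatter).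

Compound 4 `CC1=CC[C@H](C(C)(C)NC(=S)N/N=C/c2cccc([N+](=O)[O-])c2)CC1` stands to compound 2 as compound 3 stands to compound 1: the change is nitro in place of chloro on an aromatic carbon. The place is not identical, the entering group sitting meta to a large group in compound 4 and ortho to a large group in compound 3, so this is the same kind of change rather than the same change. Within the data shown here, its only measured instance, from compound 1 to compound 3, gave a 1.8-fold lower number from compound 1 to compound 3 (0.25 log units; within the scatter) and stayed within the scatter. On that single precedent the step in this assay is expected to be about a 1.7-fold lower number from compound 2 to compound 4 (0.24 log units; within the scatter), resting on compound 3 giving 8500 nM against compound 1. Compound 4 is accordingly estimated at 7800 nM, with an expected range of 3900 nM to 15600 nM.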

Compound 4, concentration for 50% growth inhibition: > 100000 nM
Compound 4: no number, only a limit; the forecaster's own chance of this, stated with the estimate: 5%; at least 12-fold (1.10 log units) between middle value and limit.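

In this assay compound 4 gives only a limit of the assay, not a number: the limit of > 100000 nM in this assay, at which 1 of the 4 values shown sits. The step stands as an at least 7.3-fold higher number from compound 2 to compound 4 (0.86 log units; beyond the scatter), so nitro in place of chloro on an aromatic carbon does not carry over from the core of compound 1 to the core of compound 2, and the two instances part clearly: the same change on two cores in this assay, a 1.8-fold lower number (0.25 log units; within the scatter) from compound 1 to compound 3 and an at least 7.3-fold higher number (0.86 log units; beyond the scatter) from compound 2 to compound 4, at least 13-fold (1.11 log units) apart, beyond the scatter of two such steps. This shows that, in this series, the result of the swap on one core cannot be taken as a guide to the other, but it gives neither the full size of the step nor a reason for the split, and two pairs set no rule for the series.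

Still open, from the compounds shown here alone, is whether the split belongs to nitro alone or also appears when other groups, such as an amine or a nitrile, replace chloro meta to a large group. The compounds shown also leave open how a methoxy group would behave at that place on the two cores.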